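Replacing bromo with nitro in compound 1

The source may hold more compounds than are shown below. What is called first, only, known or untested is meant among the compounds shown, and "the series" means these compounds.

Three compounds carry a result in a functional assay on PC-3 cells (Homo sapiens) for antiproliferative activity, read by MTT assay, with a stated time of 72 h; on this read-out lower numbers stand for stronger inhibition and higher numbers for weaker inhibition. Within the data shown here, compound 1 `O=C(COc1ccc(C(=O)/C=C/c2cccc(Br)c2)cc1)N[C@H]1CCOC1=O` is the only member with a measured number: in this assay compound 1 gives 7890 nM. Compound 2 `CC(C)c1ccc(NCC(=O)N[C@H]2CCOC2=O)cc1` reaches only a limit of the assay, > 64000 nM. Compound 3 `O=C1OCC[C@@H]1NC(=S)SCCOc1ccccc1` likewise stops at a limit of the assay, > 64000 nM. Among the measured compounds shown here, two of the three results therefore sit at the limit of > 64000 nM in this assay, at which 2 of the 3 values shown sit, so compound 1 stands alone as the one compound with a usable number, and no step between two measured compounds exists to set a scale for the series.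

Compound 4 `O=C(COc1ccc(C(=O)/C=C/c2cccc([N+](=O)[O-])c2)cc1)N[C@H]1CCOC1=O` is not yet measured. It differs from compound 1 in one place: nitro in place of bromo on an aromatic carbon, the same difference read one bond further out being 3-bromophenyl to 3-nitrophenyl. For the measured compounds named here, with no measured step to lean on, the expected step is a 1.1-fold lower number from compound 1 to compound 4 (0.05 log units; within the scatter), that is, nothing beyond the scatter. For compound 4 the estimate in this assay is 7000 nM, with a range from 2500 nM to 20000 nM.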

Compound 4, half-maximal inhibitory concentration: 56300 nM
Estimate against measurement, compound 4: 8.0-fold (0.91 log units) below; measured number outside the range, above it.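

The position meta to a large group does not tolerate every substituent: in this assay, nitro in place of bromo gives a 7.1-fold higher number from compound 1 to compound 4 (0.85 log units; beyond the scatter). Among these compounds, this is the first step that sets a scale, and it shows that the number for compound 1 depends on this single substituent as well as on the shared core. Compound 4 keeps a measured number, but it moves towards the point where compound 2 and compound 3 stop at a limit of the assay: the limit of > 64000 nM in this assay, at which 2 of the 4 values shown sit.

With one replacement at this position, the data cannot show whether the weaker number follows from the arrival of nitro or the departure of bromo. Chloro, methyl or an amine at the same position would help separate the two, as would a look at whether bromo is needed at this position at all.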